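Chloro to Bromo: One Change Across Two Cores

The source may hold more compounds than are shown below. What is called first, only, known or untested is meant among the compounds shown, and "the series" means these compounds.

Compound 1 `Cn1cc(C2CC(c3ccc(Cl)cc3)=NN2C(=O)c2cccnc2)c2cc(Br)ccc21` and compound 2 `Cn1cc(C2CC(c3ccc(Br)cc3)=NN2C(=O)c2cccnc2)c2cc(Br)ccc21` share one core and differ in a single place: bromo in place of chloro on an aromatic carbon. In a functional assay on HepG2 cells (Homo sapiens) for inhibition, read by MTT assay, with a stated time of 48 h (a higher number here means a weaker inhibitor of growth, a lower number a stronger inhibitor of growth), compound 1 gives 5800 nM, and compound 2 gives 6910 nM; the step is a 1.2-fold higher number from compound 1 to compound 2 (0.08 log units; within the scatter). Compound 3 `COc1ccc2c(c1)c(C1CC(c3ccc(Cl)cc3)=NN1C(=O)c1ccc(OC)nc1)cn2C` is built on a different core, and how it differs from compound 1 is not broken down here. In this assay compound 3 gives 2080 nM, the lowest of the three numbers and beyond the scatter from both others. Compound 4 `COc1ccc2c(c1)c(C1CC(c3ccc(Br)cc3)=NN1C(=O)c1ccc(OC)nc1)cn2C` has not yet been measured and differs from compound 3 in one place: bromo in place of chloro on an aromatic carbon. The place around it is the same as before, and this is the same change. Compound 4 is expected to move by a 1.2-fold higher number from compound 3 to compound 4 (0.06 log units; within the scatter), an expectation resting on a 1.2-fold higher number from compound 1 to compound 2 (0.08 log units; within the scatter). The estimate for compound 4 in this assay is 2400 nM.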

Compound 4, concentration for 50% growth inhibition: > 10000 nM
Compound 4: no number, only a limit; the forecaster's own chance of this, stated with the estimate: 0%; at least 4.1-fold (0.61 log units) between middle value and limit.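

In this assay compound 4 gives > 10000 nM, a limit of the assay and not a number. That makes the step of an at least 4.8-fold higher number from compound 3 to compound 4 (0.68 log units; beyond the scatter), and the small step seen on the other core does not carry over to this one: the same change on two cores in this assay, a 1.2-fold higher number (0.08 log units; within the scatter) from compound 1 to compound 2 and an at least 4.8-fold higher number (0.68 log units; beyond the scatter) from compound 3 to compound 4, at least 4.0-fold (0.60 log units) apart, beyond the scatter of two such steps. The result shows that the effect of this change on one core cannot be assumed for the other in this series, but it does not show the full size of the step or which feature of the two cores sets them apart.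

Within the data shown here, with only two pairs, any wider rule remains open. Also open, going by these compounds, is how either core would respond to fluoro, methyl or an amine on that same aromatic carbon.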